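Methoxy to Ethoxy on an Aromatic Amine Substituent

A few compounds are considered here, and "the series" means these few. Any claim that something is new, unique, unknown or untested is made for them only; others in the source may bear on it.

Compound 1, `CCCc1ccc(NC2=CC(=O)c3c(nc4n3[C@H]3OC[C@@H](O)[C@H]3OC4)C2=O)cc1`, 1920 nM
Compound 2, `COc1ccccc1NC1=CC(=O)c2c(nc3n2[C@H]2OC[C@@H](O)[C@H]2OC3)C1=O`, 1670 nM

Both compounds share the same core and differ only in the aromatic group attached to an amine nitrogen. In a functional assay on MGC-803 cells (Homo sapiens) for inhibition, read by sulforhodamine B assay (a higher number here means a weaker inhibitor, a lower number a stronger inhibitor), compound 1 gives 1920 nM. Compound 2 gives 1670 nM. The step of a 1.1-fold lower number from compound 1 to compound 2 (0.06 log units; within the scatter) is small. Compound 2 therefore has the lower of the two numbers, but the gap to compound 1 lies within the scatter, so the two compounds read alike.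

Compound 3, `CCOc1ccccc1NC1=CC(=O)c2c(nc3n2[C@H]2OC[C@@H](O)[C@H]2OC3)C1=O`, has not yet been measured. It differs from compound 2 by methyl in place of hydrogen on a saturated chain carbon bound to an oxygen on an aromatic ring. Going by the values given here, no measured step concerns this kind of change; the single step, a 1.1-fold lower number from compound 1 to compound 2 (0.06 log units; within the scatter), exchanged the whole aromatic group and still stayed within the scatter. The change from methoxy to ethoxy is thus expected to shift the number little, if at all. Compound 3 is expected to give 1700 nM, within 700 nM to 4000 nM, an expected step of a 1.0-fold higher number from compound 2 to compound 3 (0.01 log units; within the scatter).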

Compound 3, half-maximal inhibitory concentration: 2830 nM
Compound 3: the middle estimate sits 1.7-fold (0.22 log units) below what was measured; measured number inside the range.
By their numbers in this assay, from the lowest: compounds 2, 1 and 3 (each within the scatter of the next).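

Methyl in place of hydrogen on a saturated chain carbon bound to an oxygen on an aromatic ring, which turns methoxy into ethoxy, gives a 1.7-fold higher number from compound 2 to compound 3 (0.23 log units; within the scatter) in this assay and so leaves compound 2 and compound 3 reading alike. Exchanging the whole aromatic group on the amine nitrogen, 2-ethoxyphenyl in place of 4-propylphenyl, gives a 1.5-fold higher number from compound 1 to compound 3 (0.17 log units; within the scatter) and so also stays within the scatter, which means that all three aromatic groups shown read alike in this cell assay. No other information bears on why these compounds read alike.

The compounds shown leave open whether a longer chain on that oxygen, such as propoxy or butoxy, would give a step beyond the scatter. They also leave open how a free hydroxyl group or an amine in place of the ethoxy group would read.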